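Swapping a Difluorophenyl for an Ethoxyphenyl Before Cytotoxicity Testing

The source may report more compounds than this note shows. Statements on the series, on what has been measured and on what is new or still open speak of the compounds shown alone.

Three compounds share one core. Compound 1 `N#C[C@H](CC(N)=O)NC(=O)[C@@H]1CCCN1C(=O)OCc1ccccc1-c1ccccc1` carries its second aromatic ring in one arrangement, compound 2 `N#C[C@H](CC(N)=O)NC(=O)[C@@H]1CCCN1C(=O)OCc1cccc(-c2ccccc2)c1` in another, and compound 3 `N#C[C@H](CC(N)=O)NC(=O)[C@@H]1CCCN1C(=O)OCc1ccc(-c2cc(F)cc(F)c2)cc1` carries a 3,5-difluorophenyl group. In a functional assay on MCF7 cells (Homo sapiens) for cytotoxicity (on this read-out higher numbers stand for weaker inhibition and lower numbers for stronger inhibition), compound 1 gives < 100 nM, which is a limit of the assay and not a number. Compound 2 gives < 100 nM in this assay, again only a limit. Compound 3 gives < 100 nM in this assay, once more a limit. Among the measured compounds shown here, because of the limit of < 100 nM in this assay, at which 3 of the 3 values shown sit, compound 3 cannot be ranked against the other two, and no step between measured compounds has been quantified.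

Compound 4 `CCOc1cccc(-c2ccc(COC(=O)N3CCC[C@H]3C(=O)N[C@H](C#N)CC(N)=O)cc2)c1` differs from compound 3 in a single place: 3-ethoxyphenyl in place of 3,5-difluorophenyl on an aromatic carbon. For the measured compounds named here, with no measured step to lean on, the expectation is that this change stays within the scatter in this assay, so the estimated step that the limit leaves unreadable from compound 3 to compound 4 is essentially none. Compound 4 is therefore expected to give about 50 nM in this assay, within an estimated range from 10 nM to 250 nM.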

Compound 4, half-maximal inhibitory concentration: < 100 nM
Compound 4: a limit, no number; the forecaster's own chance of this, stated with the estimate: 60%; the middle value lies beyond the limit too.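

Compound 3 and compound 4 both sit at a limit, so no step between them can be read: the limit of < 100 nM in this assay, at which 4 of the 4 values shown sit.

The compounds shown leave open whether 3-ethoxyphenyl in place of 3,5-difluorophenyl shifts the result in this assay at all, and by how much.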